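This account rests on a few compounds, and the source may have more. Where it says the series, first, only, none or still open, it means among the compounds named here.

Compound 1 `Cc1c2c(n3c1CCN(C(=O)[C@H](C)N)CC[C@H](C)Nc1cc-3ccc1C(N)=O)CC(C)(C)CC2=O`: > 0.5 h
Compound 2 `Cc1c2c(n3c1CCN(C(=O)[C@@H](N)C(C)C)C[C@@H](C)[C@H](C)Nc1cc-3ccc1C(N)=O)CC(C)(C)CC2=O`: 0.217 h

Both readings come from an in vitro ADME assay on microsomes (Rattus norvegicus) for metabolic stability; a higher number here means that the compound lasts longer, a lower number that the compound disappears faster. For compound 1 the reading of > 0.5 h is a limit of the assay, not a number. Within the data shown here, compound 2 gives 0.217 h, the only exact number so far. Its reading is the lower of the two, though the pair differs in more than one place.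

Compound 3 `Cc1c2c(n3c1CCN(C(=O)[C@H](C)O)C[C@@H](C)[C@H](C)Nc1cc-3ccc1C(N)=O)CC(C)(C)CC2=O` is the next to be read. Against compound 2 it shows (1-hydroxyethyl in place of 1-amino-2-methylpropyl on a carbonyl carbon), with 1-hydroxyethyl in place of 1-amino-2-methylpropyl on a carbonyl carbon. Among the measured compounds shown here, no measured step covers this change, so the expectation rests on the single number for compound 2, 0.217 h. The expected move is a 1.5-fold higher number from compound 2 to compound 3 (0.18 log units; within the scatter), a modest rise that probably stays within the scatter. For compound 3 the estimated half-life is 0.33 h, with an expected range of 0.14 h to 0.8 h.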

Compound 3, half-life: 0.483 h
Compound 3: the middle estimate sits 1.5-fold (0.17 log units) below what was measured, and the stated range covers the measured number.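

In this assay, the position on the carbonyl carbon whose other neighbour is the amide-type nitrogen in a ring now has its first readable step: 1-hydroxyethyl in place of 1-amino-2-methylpropyl gives a 2.2-fold higher number from compound 2 to compound 3 (0.35 log units; beyond the scatter). The change is not a single swap of one atom: 5 heavy atoms leave and 3 enter, with nitrogen replaced by oxygen and the chain shortened in the same step, while the donor and acceptor counts stay equal. The remaining reading in the series is a limit for compound 1, not a number: the limit of > 0.5 h in this assay, at which 1 of the 3 values shown sits.

Which part of the change carries the step stays open, and a 1-hydroxy-2-methylpropyl group on this carbonyl carbon would separate the oxygen from the chain length. As far as these compounds go, how a 1-methoxyethyl group or a carboxylic acid reads here is also open.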